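The source may report more compounds than this note shows. Statements on the series, on what has been measured and on what is new or still open speak of the compounds shown alone.

Compound 3 `COc1ccc(CNC(=O)CSc2nc3ccc(NC(C)=O)cc3s2)cc1` stands second highest of the three numbers in a functional assay on HepG2 cells (Homo sapiens) for cytotoxicity, read by MTT assay, with a stated time of 48 h (on this read-out higher numbers stand for weaker inhibition and lower numbers for stronger inhibition), where compound 3 gives 11200 nM. Its nearest neighbour is compound 1 `COc1ccc(CNC(=O)CSc2nc3ccc(NC(=O)c4ccc(Cl)cc4)cc3s2)cc1`, which in this assay gives 7400 nM; further off, compound 2 `O=C(CSc1nc2ccc(NC(=O)c3ccccc3)cc2s1)NCc1ccc(Cl)cc1` gives 30100 nM. The change to compound 4 `COc1ccc(CNC(=O)CSc2nc3ccc(NC(=O)c4ccccc4)cc3s2)cc1` is phenyl in place of methyl on a carbonyl carbon. Among the measured compounds shown here, the only measured step that bears on it is a 1.5-fold higher number from compound 1 to compound 3 (0.18 log units; within the scatter), which runs in the opposite direction and points to a step no larger than the scatter. For the measured compounds named here, compound 2 carries the benzamido group of compound 4 but differs elsewhere too, so no single step can be drawn from it. The expected step is therefore a 1.2-fold lower number from compound 3 to compound 4 (0.09 log units; within the scatter). Compound 4 is estimated at 9000 nM, with a range from 4000 nM to 25000 nM.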

Compound 4, half-maximal inhibitory concentration: 12700 nM
Compound 4: middle estimate off by 1.4-fold (0.15 log units), on the low side, within the range that was stated.
By their numbers in this assay, from the lowest: compounds 1, 3 and 4 (each within the scatter of the next); then compound 2.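

In this assay, methyl and phenyl on this carbonyl carbon are not told apart, with a 1.1-fold higher number from compound 3 to compound 4 (0.05 log units; within the scatter). Hydrogen in place of chloro on an aromatic carbon is likewise unresolved, with a 1.7-fold higher number from compound 1 to compound 4 (0.23 log units; within the scatter). Among the compounds shown here, the only step beyond the scatter is the modest one for methoxy in place of chloro on an aromatic carbon, with a 2.4-fold lower number from compound 2 to compound 4 (0.37 log units; beyond the scatter).

No supporting data bear on any of these steps. From the compounds shown here alone, whether an amine or a longer alkyl chain on this carbonyl carbon would separate from methyl and phenyl remains open.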